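1,3-Thiazol-2-yl for 5-methyl-1,2-oxazol-3-yl on the amide nitrogen

The source may report more compounds than this note shows. Statements on the series, on what has been measured and on what is new or still open speak of the compounds shown alone.

Measured so far in a functional assay on BMDM cells (Mus musculus, strain C57BL/6) for inhibition, with a stated time of 2 days; a lower number here means a stronger inhibitor, a higher number a weaker inhibitor. Compound 1, `Cc1cc(NC(=O)Cn2cc(-c3ccc(C#N)cc3)nn2)no1`, gives 9320 nM. Compound 2, `O=C(Cn1cc(-c2ccccc2Cl)nn1)Nc1nccs1`, gives 60 nM. Compound 3, `Cc1cc(NC(=O)Cn2cc(-c3ccccc3Cl)nn2)no1`, returns only a limit of the assay, > 30000 nM, and no number.

Compound 3 and compound 2 differ in one place: 1,3-thiazol-2-yl in place of 5-methyl-1,2-oxazol-3-yl on an amide-type nitrogen. The measured step is an at least 500-fold lower number from compound 3 to compound 2 (2.69 log units; beyond the scatter). Its true size is open because the limit of > 30000 nM in this assay, at which 1 of the 3 values shown sits, is where compound 3 sits, so the step can only be given as a bound. Of the two numbers available, compound 1 has the higher one and compound 2 the lower, a gap that lies beyond the scatter. The difference between the core of compound 1 and the core of compound 3 is not broken down here.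

Compound 4, `N#Cc1ccc(-c2cn(CC(=O)Nc3nccs3)nn2)cc1`, is not yet measured. It carries the same change relative to compound 1 that compound 2 carries relative to compound 3: 1,3-thiazol-2-yl in place of 5-methyl-1,2-oxazol-3-yl on an amide-type nitrogen. The place is the same word for word in both pairs, so this is the same change, made a second time. The expected step from compound 1 to compound 4 in this assay is a 310-fold lower number from compound 1 to compound 4 (2.49 log units; beyond the scatter). This expectation rests on an at least 500-fold lower number from compound 3 to compound 2 (2.69 log units; beyond the scatter), a step that can only be given as a bound. It also rests on the starting value of compound 1, which is 9320 nM. For compound 4 the estimated value is 30 nM, with the range expected to run from 6 nM to 200 nM.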

Compound 4, half-maximal inhibitory concentration: 270 nM
Beside the measured number, compound 4's estimate is 9.0-fold (0.95 log units) below it; measured number outside the range, above it.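

In this assay the change from 5-methyl-1,2-oxazol-3-yl to 1,3-thiazol-2-yl on the amide-type nitrogen gives a 35-fold lower number from compound 1 to compound 4 (1.54 log units; beyond the scatter), so the direction of the step is the same on both cores shown. The size of the step does not carry over from one core to the other: the same change on two cores in this assay, an at least 500-fold lower number (2.69 log units; beyond the scatter) from compound 3 to compound 2 and a 35-fold lower number (1.54 log units; beyond the scatter) from compound 1 to compound 4, at least 14-fold (1.16 log units) apart, beyond the scatter of two such steps Compound 3 gives a limit of the assay and not a number, so the earlier step and the gap between the two steps remain bounds, and two cores do not show what size the step would take on a third: the limit of > 30000 nM in this assay, at which 1 of the 4 values shown sits.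

Still open, from the compounds shown here alone, is how the step behaves on a core carrying a methoxy or trifluoromethyl group in place of the nitrile or the chlorine, which would show whether the two steps seen here are part of a wider trend. Also open, going by these compounds, is whether a pyridin-2-yl group or an unsubstituted 1,2-oxazol-3-yl group on the amide-type nitrogen would give numbers closer to those with 1,3-thiazol-2-yl or to those with 5-methyl-1,2-oxazol-3-yl.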